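Compound 2 Loses a Chloro: An Expected Half-Life

The source may report more compounds than this note shows. Statements on the series, on what has been measured and on what is new or still open speak of the compounds shown alone.

Values so far in an in vitro ADME assay on microsomes (Homo sapiens) for metabolic stability; a higher number here means that the compound lasts longer, a lower number that the compound disappears faster
Compound 1 `CCc1nc(NC(CC)CC)c(OC)nc1-c1ccc(OC(F)F)cc1Cl` gives 2 h
Compound 2 `CCc1nc(NC(CC)CC)c(Cl)nc1-c1ccc(Cl)cc1Cl` gives 0.167 h
Compound 3 `CCc1nc(-c2ccc(OC)cc2OC(F)(F)F)c(CC)nc1NC(CC)CC` gives 0.267 h

Compound 2 (0.167 h) and compound 3 (0.267 h) lie within the scatter of each other. Compound 1 (2 h) has a higher number, and its gap to compound 2 lies beyond the scatter.

The next compound is compound 4 `CCc1nc(NC(CC)CC)cnc1-c1ccc(Cl)cc1Cl` and it is reached from compound 2 through one change, hydrogen in place of chloro on an aromatic carbon. Among the measured compounds shown here, no pair of measured compounds differs in one place only, so the data give no direct measure of such a change. The expectation therefore rests on the parent, compound 2 (0.167 h), and on the small size of the change. The expected 1.2-fold higher number from compound 2 to compound 4 (0.08 log units; within the scatter) stays within the scatter, so no clear shift in either direction is expected in this assay for this change. The estimated half-life of compound 4 is 0.2 h (expected range 0.08 h to 0.5 h).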

Compound 4, half-life: 0.467 h
Beside the measured number, compound 4's estimate is 2.3-fold (0.37 log units) below it; measured number inside the range.
By their numbers in this assay, from the lowest: compounds 2, 3 and 4 (each within the scatter of the next, the first and the last beyond it); then compound 1.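

Among the compounds shown here, this is the first comparison here in which only one place differs. In this assay, hydrogen in place of chloro on the aromatic carbon next to the ring nitrogen, ortho to the (pentan-3-yl)amino group, gives a 2.8-fold higher number from compound 2 to compound 4 (0.45 log units; beyond the scatter). The position is therefore not indifferent to what it carries: the loss of this one chlorine, with no heavy atom entering, is enough to raise the half-life by a modest step, and nothing measured here accounts for the shift.

From the compounds shown here alone, this change is seen only once, on the core of compound 2, so it remains open whether the same step would appear with other groups elsewhere on the molecule. Going by these compounds, what a fluoro, a nitrile or an amine at this position would do in this assay also remains open.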